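The compounds below may be only part of what the source reports. "The series", "measured", "known", "first", "only" and "open" are said of these compounds alone.

Of the compounds shown here, two have been tested so far in a functional assay on the whole organism with Mus musculus as the target; on this read-out lower numbers stand for an effect already at smaller amounts and higher numbers for an effect only at larger amounts of compound. Compound 1, `C=CCNC(=O)/C(C)=C/c1ccccc1`, carries an allyl group on its amide nitrogen; in this assay compound 1 gives 53.8 mg/kg. Compound 2, `C/C(C(N)=O)=C(/C)c1ccc(Cl)cc1`, carries an unsubstituted amide and, on its aromatic ring, a chlorine; in this assay compound 2 gives 20.9 mg/kg. Of the two numbers that of compound 2 is the lower one, and the gap to compound 1 lies beyond the usual scatter; the two structures differ in more than one place, so this gap cannot be tied to any single change.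

Compound 3, `C=CCNC(=O)/C(C)=C(\C)c1ccc(Cl)cc1`, differs from compound 2 in one place: allyl in place of hydrogen on an amide-type nitrogen. Among the compounds with values here, no measured pair shows this change on its own. Compound 1 bears the same allyl amide but lacks the other features of compound 2; in this assay compound 1 gives 53.8 mg/kg, which points weakly toward a higher number. Compound 3 is therefore expected to give 28 mg/kg, within the range 14 mg/kg to 60 mg/kg, a step of a 1.3-fold higher number from compound 2 to compound 3 (0.13 log units; within the scatter) that is estimated to stay near the edge of the scatter.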

Compound 3, dose for half-maximal effect: 18.6 mg/kg
Compound 3: the middle estimate sits 1.5-fold (0.18 log units) above what was measured; low and high end bracket the measured number.
By their numbers in this assay, from the lowest: compounds 3 and 2 (each within the scatter of the next); then compound 1.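

Putting allyl in place of hydrogen on the amide-type nitrogen gives a 1.1-fold lower number from compound 2 to compound 3 (0.05 log units; within the scatter) in this assay for this pair. Within the data shown here, this is the first pair to show the change on its own, and it shows that, on the core of compound 2, the amide hydrogen can give way to allyl without any shift that stands out from the scatter. The allyl amide of compound 1 had hinted at a higher number, but this clean comparison does not bear that hint out, so the allyl group alone gives no reason to expect a loss on this core.

Nothing measured here explains why this nitrogen accepts the change so readily, and the reason stays unknown. From the compounds shown here alone, it also remains open whether larger or different groups on the same nitrogen, such as a longer chain like butyl, a benzyl group or a chain ending in an amine, would also leave the number within the scatter, and whether allyl would behave the same way on the core of compound 1.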